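The source may report more compounds than this note shows. Statements on the series, on what has been measured and on what is new or still open speak of the compounds shown alone.

Measured so far in a functional assay on A549 cells (Homo sapiens) for cytotoxicity, read by MTT assay, with a stated time of 72 h; a higher number here means a weaker inhibitor, a lower number a stronger inhibitor:
- compound 1 `COc1cccc(/C=C2\CCC/C(=C\c3cc(OC)c(OC)c(OC)c3)C2=O)c1OC`: 5900 nM
- compound 2 `COc1ccc(/C=C2\CCC/C(=C\c3ccc(OC)c(OC)c3)C2=O)cc1OC`: 8500 nM
- compound 3 `COc1cc(/C=C2\CCC/C(=C\c3ccc(OC)c(OC)c3)C2=O)cc(OC)c1`: 5100 nM

All three share one core and carry only methoxy groups on their aromatic rings. Compound 3, at 5100 nM, stands within the scatter of both other compounds, so this assay does not separate it from either. Compound 1 and compound 2 also lie within the scatter of each other. No two of the measured compounds differ in only one place, so the series offers no direct measure of a single change.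

The next compound is compound 4 `COc1ccc(/C=C2\CCC/C(=C\c3cc(OC)c(OC)c(OC)c3)C2=O)cc1OC`. Relative to compound 3 the change is methoxy in place of hydrogen on an aromatic carbon, ortho to two methoxy groups and para to a large group.

The expectation rests on the narrow spread of the series, from compound 3 at 5100 nM to compound 2 at 8500 nM, with compound 1 at 5900 nM inside that spread. No shift beyond the scatter is expected, and the direction is left open. The expected change is a 1.2-fold higher number from compound 3 to compound 4 (0.07 log units; within the scatter). The estimated value for compound 4 is 6000 nM, with an expected range from 2800 nM to 13000 nM.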

Compound 4, half-maximal inhibitory concentration: 2900 nM
For compound 4 the middle estimate is 2.1-fold (0.32 log units) above the measured one, and the stated range covers the measured number.
By their numbers in this assay, from the lowest: compounds 4, 3, 1 and 2 (each within the scatter of the next, the first and the last beyond it).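

In this assay, methoxy in place of hydrogen on an aromatic carbon, ortho to two methoxy groups and para to a large group, gives a 1.8-fold lower number from compound 3 to compound 4 (0.25 log units; within the scatter) and so cannot be told apart from no change at this position. Methoxy in place of hydrogen on an aromatic carbon also gives a 2.9-fold lower number from compound 2 to compound 4 (0.47 log units; beyond the scatter) and 3,4-dimethoxyphenyl in place of 2,3-dimethoxyphenyl gives a 2.0-fold lower number from compound 1 to compound 4 (0.31 log units; beyond the scatter), so the series now holds its first single-place steps beyond the scatter, both modest, and both ending at compound 4. No measurement at hand bears on why these steps take the size they do.

On these data alone, all four compounds carry only methoxy groups on their aromatic rings, so it remains open whether a hydroxyl, an amine, a carboxylic acid or a longer chain such as butoxy on the same aromatic carbon would give a step beyond the scatter from compound 3. As far as these compounds go, the steps also come from one cell line and one read-out, so it remains open whether the modest steps to compound 4 would hold on other cells.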